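This account rests on a few compounds, and the source may have more. Where it says the series, first, only, none or still open, it means among the compounds named here.

The starting point is compound 1, `CN(C)C(=O)c1c[nH]c2ccccc12`, tested in a physicochemical assay for solubility, with a stated time of 24 h, at pH 4.5; on this read-out higher numbers stand for higher solubility and lower numbers for lower solubility. Compound 1 gives > 47 ug/mL, which is a limit and not a number. Compound 2, `CN(C)C(=O)c1ccc2cccccc1-2`, also gives a limit, > 44 ug/mL. Compound 3, `O=C(Cn1ccccc1=O)Nc1cc2ccccc2[nH]1`, likewise gives a limit, > 67 ug/mL. All three results are therefore limits, so compound 1 cannot be ranked against the other two.

The next compound, compound 4, `CN(C)C(=O)c1cn(C)c2ccccc12`, keeps the core of compound 1 and differs in one place: methyl in place of hydrogen on an aromatic nitrogen. This puts methyl in place of hydrogen on an aromatic nitrogen, two ring bonds from the ring atom that bears a dimethylcarbamoyl group. Among the compounds with values here, no measured pair shows what such a change does in this assay. Resting on the limit of compound 1, > 47 ug/mL, no step beyond the usual scatter is expected. Compound 4 may well return a limit too. The expected change is a step that the limit leaves unreadable from compound 1 to compound 4. For compound 4 the estimated value is 50 ug/mL, with an expected range of 30 ug/mL to 70 ug/mL.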

Compound 4, solubility: > 51 ug/mL
Compound 4 was reported as a limit (the forecaster's own chance of this, stated with the estimate: 80%); at least 1.0-fold (0.00 log units) between middle value and limit.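

The results for compound 1 and compound 4 are both limits, so no step can be read between them. The compounds shown leave open what methyl in place of hydrogen on an aromatic nitrogen does to solubility, and how these compounds truly rank.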